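This account rests on a few compounds, and the source may have more. Where it says the series, first, only, none or still open, it means among the compounds named here.

Working notes on the series. In a functional assay on CWR22R cells (Homo sapiens) for antiproliferative activity, read by CCK-8 assay, with a stated time of 6 days (a higher number here means a weaker inhibitor, a lower number a stronger inhibitor), compound 1 (`CC(O)c1cccc(C(=O)N[C@@H](C)Cn2ccc(-c3ccc(C#N)c(Cl)c3)n2)c1`) gives 20100 nM and compound 2 (`CC(O)c1ccc(C(=O)N[C@@H](C)Cn2ccc(-c3ccc(C#N)c(Cl)c3)n2)cc1`) gives 9050 nM. Compound 3 (`C[C@@H](Cn1ccc(-c2ccc(C#N)c(Cl)c2)n1)NC(=O)C1CC(=O)C1`) has no usable number, its entry reading "not determined" (no result reported), so it offers no starting value for the next step.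

Compound 4 (`C[C@@H](Cn1ccc(-c2ccc(C#N)c(Cl)c2)n1)Nc1ncccn1`) has pyrimidin-2-yl in place of (3-oxocyclobutyl)carbonyl on an amine nitrogen.

Among the compounds with values here, the only measured step is a 2.2-fold lower number from compound 1 to compound 2 (0.35 log units; beyond the scatter). It is modest, though beyond the scatter, and it concerns a different change on a carbonyl carbon, so it bears only indirectly on this replacement. Within the data shown here, no measured step covers the exchange at the amine nitrogen. No size or direction of change from compound 3 can therefore be expected in this assay. The estimate instead rests on the general level set by compound 1 at 20100 nM and compound 2 at 9050 nM, with a wide range to reflect the missing anchor. Compound 4 is expected at 9000 nM, with an estimated range of 2000 nM to 35000 nM.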

Compound 4, half-maximal inhibitory concentration: 12500 nM
Estimate against measurement, compound 4: 1.4-fold (0.14 log units) below; low and high end bracket the measured number.
By their numbers in this assay, from the lowest: compounds 2, 4 and 1 (each within the scatter of the next, the first and the last beyond it).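

No new step can be read, since compound 3 has no number to set against compound 4 in this assay. The compounds shown leave open how pyrimidin-2-yl compares with (3-oxocyclobutyl)carbonyl on the amine nitrogen. No supporting data bear on the result for compound 4.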